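The source may report more compounds than this note shows. Statements on the series, on what has been measured and on what is new or still open speak of the compounds shown alone.

In an ADME assay on MT4 cells (Homo sapiens) for cytotoxicity, read by MTT assay, with a stated time of 5 days (a higher number here means that more compound is tolerated, a lower number that less compound is tolerated), compound 1, built as `Cc1cc(OCC(=O)Nc2ccc([N+](=O)[O-])cc2)nc(Nc2ccc(C#N)cc2)n1`, is tolerated up to a limit of the assay rather than a number, so that compound 1 shows > 309000 nM. Compound 2, built as `Cc1cc(OCC(=O)Nc2ccc(C#N)cc2F)nc(Nc2ccc(C#N)cc2)n1`, likewise reaches only a limit, and in this assay compound 2 shows > 310000 nM. The change between them is 4-cyano-2-fluorophenyl in place of 4-nitrophenyl on an amide-type nitrogen. The resulting step that the two limits leave unreadable from compound 1 to compound 2 cannot be read because the limit of > 309000 nM in this assay, at which 1 of the 3 values shown sits, and the limit of > 310000 nM in this assay, at which 1 of the 3 values shown sits, are both limits and leave no number to compare.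

Compound 3, built as `Cc1cnc(Nc2ccc(C#N)cc2)nc1OCC(=O)Nc1ccc([N+](=O)[O-])cc1`, has the same atoms as compound 1 joined differently; the difference between the two cores is not broken down here. Within the data shown here, compound 3 is the only compound of the three with a measured number, and in this assay compound 3 gives 66300 nM.

Compound 4, built as `Cc1cnc(Nc2ccc(C#N)cc2)nc1OCC(=O)Nc1ccc(C#N)cc1F`, has not been measured. It differs from compound 3 by 4-cyano-2-fluorophenyl in place of 4-nitrophenyl on an amide-type nitrogen, which is the same change that leads from compound 1 to compound 2, made at the same kind of place. Since that earlier step was left unreadable by the two limits, no measured size is available to guide the expectation, and the step of a 1.7-fold higher number from compound 3 to compound 4 (0.22 log units; within the scatter) is expected to be modest. Compound 4 is therefore estimated to show 110000 nM in this assay, with an expected range from 30000 nM to 310000 nM, and a fair chance that only a limit is reported.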

Compound 4, half-maximal cytotoxic concentration: > 310000 nM
Compound 4 gave a limit, no number; the forecaster's own chance of this, stated with the estimate: 40%; middle value at least 2.8-fold (0.44 log units) from the limit.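

In this assay, putting 4-cyano-2-fluorophenyl in place of 4-nitrophenyl on the amide-type nitrogen gives an at least 4.6-fold higher number from compound 3 to compound 4 (0.66 log units; beyond the scatter), so on the core of compound 3 the change goes with more compound being tolerated, by a margin beyond the usual scatter. Compound 4 gives a limit and not a number, so the printed size is only the smallest the step can be: the limit of > 310000 nM in this assay, at which 2 of the 4 values shown sit.

The same change from compound 1 to compound 2 cannot be read, as both values there are limits; this pair neither supports nor contradicts the new step, so the series shows a readable effect of the change on one core only and does not show that its size or direction carries over from one core to the other.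

As far as these compounds go, it stays open which part of the change goes with the step: the loss of the nitro group, the nitrile or the fluorine, and a plain 4-cyanophenyl group on that nitrogen would help to separate these. From the compounds shown here alone, it also stays open how tolerance in this assay would respond on either core to a 4-aminophenyl group or a 4-carboxyphenyl group at the same place.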